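Hydroxamic Acids on a Shared Core: Bromo to Chloro

The compounds below may be only part of what the source reports. "The series", "measured", "known", "first", "only" and "open" are said of these compounds alone.

Measured compounds:
compound 1 `Cc1ccc(CN2CC=C(CCC(=O)NO)C2=O)cc1` with 4280 nM in a functional assay on NUGC-3 cells (Homo sapiens) for inhibition, read by sulforhodamine B assay; on this read-out higher numbers stand for weaker inhibition of growth and lower numbers for stronger inhibition of growth
compound 2 `O=C(CCC1=CCN(Cc2ccc(Br)cc2)C1=O)NO` with "not determined" (no result reported) in this assay

Compound 2 stands without a number in this assay, so its position cannot be placed against compound 1. Compound 3 `O=C(CCC1=CCN(Cc2ccc(Cl)cc2)C1=O)NO` differs from compound 2 by chloro in place of bromo on an aromatic carbon. With no measured step of this kind among the compounds shown, the change from compound 2 to compound 3 is expected to move this assay by no more than the usual scatter, in no set direction. Compound 3 is expected to give 4000 nM, within a range from 1300 nM to 12000 nM. This expectation leans on compound 1, which gives 4280 nM in this assay.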

Compound 3, concentration for 50% growth inhibition: 4280 nM
Compound 3: the middle estimate sits 1.1-fold (0.03 log units) below what was measured, within the range that was stated.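

In this assay, within the data shown here, exchanging the methyl group for a chloro group, para to a large group, gives no change at the digits printed from compound 1 to compound 3 (within the scatter) as the first readable step at this position, so this read-out does not separate these two groups here. The step from bromo to chloro cannot be read, as compound 2 has no number. No measurement shown offers an explanation for this result.

Still open, as far as these compounds go, is whether an amine or a methoxy group at this position would move growth inhibition beyond the scatter. Also open, from the compounds shown here alone, is what a longer chain to the hydroxamic acid would do.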